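Cyclohexyl to Pentan-3-yl: Expected Cytotoxicity of Compound 3

The compounds below may be only part of what the source reports. "The series", "measured", "known", "first", "only" and "open" are said of these compounds alone.

Of the compounds shown here, two have been measured in an ADME assay on HepG2 cells (Homo sapiens) for cytotoxicity, read by luminescence, CellTiter-Glo and ATP content, with a stated time of 72 h; a lower number here means that less compound is needed, a higher number that more compound is needed for the effect. Compound 1 `COc1ccccc1Oc1ccc2c(NCCCNCc3ccco3)ccnc2c1` gives 6500 nM. Compound 2 `COc1ccc(F)cc1CNCCCNc1ccnc2cc(C3CCCCC3)ccc12` gives 2290 nM in this assay, the lowest of the two numbers; its nearest neighbour is compound 1, which stands higher by a gap beyond the usual scatter. Going by the values given here, no pair of measured compounds differs in a single place, so no individual step has yet been characterised.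

Compound 3 `CCC(CC)c1ccc2c(NCCCNCc3cc(F)ccc3OC)ccnc2c1` has not yet been measured. It differs from compound 2 in one place: pentan-3-yl in place of cyclohexyl on an aromatic carbon. Both the leaving and the entering group carry no hydrogen-bond donors or acceptors and no net charge, and they differ by a single heavy atom. The step of a 1.2-fold higher number from compound 2 to compound 3 (0.09 log units; within the scatter) is therefore expected to be small, at most a slight move toward a higher number, quite possibly within the scatter. In this assay compound 3 is expected to give 2800 nM, with a range from 1100 nM to 7000 nM.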

Compound 3, half-maximal effective concentration: 7860 nM
Estimate against measurement, compound 3: 2.8-fold (0.45 log units) below; the whole stated range lies below it.
By their numbers in this assay, from the lowest: compound 2; then compounds 1 and 3 (each within the scatter of the next).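

In this assay, the change from cyclohexyl to pentan-3-yl on this aromatic carbon brings a 3.4-fold higher number from compound 2 to compound 3 (0.54 log units; beyond the scatter), the first single-place step available in this series. It shows that the position is sensitive to this exchange, even though the two groups differ by a single heavy atom and match in hydrogen-bond donors, acceptors and net charge; this one step cannot separate the loss of the ring from the loss of one carbon. No measurement shown here bears on why the number rises.

On these data alone, it remains open whether a cyclopentyl group, which keeps a ring with the same carbon count as pentan-3-yl, would stay close to compound 2 or move with compound 3. How a morpholine or a tert-butyl group at this carbon would read is also unknown.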